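A few compounds are considered here, and "the series" means these few. Any claim that something is new, unique, unknown or untested is made for them only; others in the source may bear on it.

Measured so far:
- Compound 1 `COc1cccc2occ(Cc3coc4ccccc4c3=O)c(=O)c12` gives 3190 nM
- Compound 2 `O=c1c(Cc2coc3cccc(OCC4CCCCC4)c3c2=O)coc2cc(O)ccc12` gives 3220 nM
- Compound 3 `O=C1c2c(OCC3CCCCC3)cccc2OCC1Cc1coc2ccccc2c1=O` gives 8420 nM

These three compounds were tested in a functional assay on NUGC-3 cells (Homo sapiens) for antiproliferative activity, read by XTT assay; a higher number here means a weaker inhibitor, a lower number a stronger inhibitor. Compound 1 has the lowest number of the three, but its gap to compound 2 lies within the scatter of repeated measurements, so the two cannot be told apart on these data. Compound 3 is clearly weaker, its number being beyond the scatter from compound 1. Within the data shown here, compound 2 and compound 3 both carry a larger chain on the aromatic oxygen than compound 1 does, and no single step between them and compound 1 has been measured.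

The step of interest leads from compound 1 to the not yet measured compound 4 `CC(C)COc1cccc2occ(Cc3coc4ccccc4c3=O)c(=O)c12`. The change is isopropyl in place of hydrogen on a saturated chain carbon bound to an oxygen on an aromatic ring. In words of the difference itself, methoxy becomes isobutoxy. Compound 2, which also carries a larger chain at an aromatic oxygen, gives a number within the scatter of compound 1, so no step beyond the scatter is expected here in either direction. The step from compound 1 to compound 4 is expected to be a 1.1-fold higher number from compound 1 to compound 4 (0.04 log units; within the scatter). Compound 4 is therefore estimated at 3500 nM, with a range from 1500 nM to 9000 nM.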

Compound 4, half-maximal inhibitory concentration: > 10000 nM
Compound 4: a limit, no number; the forecaster's own chance of this, stated with the estimate: 5%; middle value at least 2.8-fold (0.45 log units) away from the limit.
By their numbers in this assay, from the lowest: compounds 1 and 2 (each within the scatter of the next); then compound 3. At a limit, above all of these: compound 4.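

In this assay, among these compounds, the step from methoxy to isobutoxy is an at least 3.1-fold higher number from compound 1 to compound 4 (0.49 log units; beyond the scatter), and this is the first measured change at this place in which only one group differs between two compounds. Isopropyl in place of hydrogen, on a saturated chain carbon bound to an oxygen on an aromatic ring, is therefore enough on its own to move the number beyond the scatter towards weaker activity, while the rest of compound 1 stays the same; the earlier compounds could not show this, as they differ from one another in more than one place. For compound 4 the reading rests on a limit of the assay and not on a number: the limit of > 10000 nM in this assay, at which 1 of the 4 values shown sits.

From the compounds shown here alone, how far the true value of compound 4 lies past that limit stays open, so the full size of the step cannot be given. Also open, going by these compounds, is where along the way from methoxy the loss sets in, and whether an ethyl or propyl chain on this oxygen, or a chain ending in an amine or a carboxylic acid, would keep the number of compound 1.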